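Swapping a carboxypyridine for a carboxypyrazine on an amide

The source may report more compounds than this note shows. Statements on the series, on what has been measured and on what is new or still open speak of the compounds shown alone.

Three compounds share a core built from a cyclopentyl-bearing chain, a trifluoromethyl-substituted imidazole and an amide; they differ only in the aromatic ring attached to the amide nitrogen. Compound 1 `Cc1ccc(NC(=O)[C@H](CC2CCCC2)n2cnc(C(F)(F)F)c2)nc1` carries a methylpyridine there, and in an ADME assay on MDCKII-LE cells (Canis lupus familiaris) for permeability (a lower number here means that the compound crosses the layer more slowly, a higher number that the compound crosses the layer faster), compound 1 gives 17.4 10^-6 cm/s. Compound 2 `O=C(O)c1ccnc(NC(=O)[C@H](CC2CCCC2)n2cnc(C(F)(F)F)c2)c1` carries a carboxypyridine instead, but for compound 2 this assay returned "not determined" (no result reported), so compound 2 stands without a single number to anchor it. Compound 3 `O=C(O)c1cnc(NC(=O)[C@H](CC2CCCC2)n2cnc(C(F)(F)F)c2)cn1` is the untested neighbour of compound 2, and the change between them is 5-carboxypyrazin-2-yl in place of 4-carboxypyridin-2-yl on an amide-type nitrogen. Going by the values given here, because no step in this assay is recorded for any pair here, the size of the shift from compound 2 to compound 3 cannot be read from measured data. Set against compound 1 at 17.4 10^-6 cm/s, compound 3 is expected to come out clearly lower, a step well beyond the scatter. For compound 3 the permeability in this assay is estimated at 1 10^-6 cm/s, with a likely range from 0.2 10^-6 cm/s to 5 10^-6 cm/s.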

Compound 3, apparent permeability: 1.1 10^-6 cm/s
For compound 3 the middle estimate is 1.1-fold (0.04 log units) below the measured one; the measured number falls inside the stated range.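

This position on the amide-type nitrogen is now shown to be sensitive in this assay: with the shared core untouched, 5-carboxypyrazin-2-yl in place of 5-methylpyridin-2-yl gives a 16-fold lower number from compound 1 to compound 3 (1.20 log units; beyond the scatter) and so provides the first measured number for a carboxylic acid at this position. That one replacement alters two things together, a methyl group giving way to a carboxylic acid and a ring with 1 hetero atom giving way to a ring with 2 hetero atoms, so the step belongs to the whole group and cannot be divided between its parts. Nothing measured among these compounds accounts for the step.

As far as these compounds go, the step from compound 2 to compound 3 cannot be read, and how far the pyrazine ring alone shifts the number stays open. A 5-methylpyrazin-2-yl group on the same nitrogen would differ from compound 1 only in the ring and from compound 3 only in having a methyl group instead of the carboxylic acid, and could show how much of the step goes with each.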